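A few compounds are considered here, and "the series" means these few. Any claim that something is new, unique, unknown or untested is made for them only; others in the source may bear on it.

Measured in an assay on HEK293 cells for activation of Kir3.1/Kir3.2 (Homo sapiens), read by thallium flux; on this read-out higher numbers stand for larger maximal responses and lower numbers for smaller maximal responses:
Compound 1, `Cc1cc(NC(=S)Cn2nnc(-c3ccccc3)n2)n(C2CCCCC2)n1`: 80%
Compound 2, `Cc1cc(NC(=O)Cn2nnc(-c3ccccc3)n2)n(C2CCS(=O)(=O)CC2)n1`: > 25%, a limit of the assay and not a number
Compound 3, `Cc1cc(NC(=O)Cn2nnc(-c3cccnc3)n2)n(C2CCCCC2)n1`: 96%

Of the two numbers recorded, compound 3 stands highest. Among the compounds with values here, the only other number, that of compound 1, lies lower by more than the usual scatter of repeated measurements, so the two are genuinely apart. Compound 2 contributes only a limit and cannot be ranked against them.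

The next compound, compound 4, `Cc1cc(NC(=O)Cn2nnc(-c3cc(Cl)cc(Cl)c3)n2)n(C2CCCCC2)n1`, differs from compound 3 in one place: 3,5-dichlorophenyl in place of pyridin-3-yl on an aromatic carbon. The shared core, the amide linker and the cyclohexyl group all stay as they are.

Within the data shown here, no pair of measured compounds shows what this exchange does in this assay, so the size of the step can only be guessed. The two numbers that exist both show a large maximal response, and nothing among them points to a loss. A modest fall is expected for compound 4, with a number 11 percentage points lower from compound 3 to compound 4 (beyond the scatter) describing the step, though a step within the scatter is just as plausible. For compound 4 in this assay the estimate is 85%, most likely between 60% and 105%.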

Compound 4, largest response reached (Emax), in percent of the reference or control that the assay uses: 82%
The estimate for compound 4 lay 3 percentage points above the measured number, and the stated range covers the measured number.
By their numbers in this assay, from the lowest: compounds 1 and 4 (each within the scatter of the next); then compound 3.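

In this assay, within the data shown here, the exchange of pyridin-3-yl for 3,5-dichlorophenyl on the aromatic carbon of the five-membered ring gives the only measured step at this position, a number 14 percentage points lower from compound 3 to compound 4 (beyond the scatter), and that step is modest. This position therefore accepts a larger group, with eight heavy atoms in place of six and with no ring nitrogen or hydrogen-bond acceptor, and compound 4 still reaches 82% as a large maximal response. The exchange alters several things at once, so the step cannot be divided between the loss of the ring nitrogen and the arrival of the two chlorine atoms, and nothing measured here gives a reason for the fall.

Still open, on these data alone, is how a ring with a single chlorine atom would behave here, which would help separate those two contributions. Also open, as far as these compounds go, is whether a ring bearing an amine or a carboxylic acid at this position would keep the maximal response as large as the two aromatic groups compared here do.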